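The source may report more compounds than this note shows. Statements on the series, on what has been measured and on what is new or still open speak of the compounds shown alone.

Measured in an ADME assay on HepG2 cells (Homo sapiens) for cytotoxicity, read by CellTiter-Glo and resazurin assay, with a stated time of 72 h (a higher number here means that more compound is needed for the effect, a lower number that less compound is needed), all three values being limits:

Compound 1 `CCOc1cccc(-c2ccc(C(=O)N(Cc3cccc(OCCCCCC(=O)O)c3)C(C)C)cc2)c1`: > 20800 nM
Compound 2 `CC(C)N(Cc1cccc(OCCCCCC(=O)O)c1)C(=O)c1ccc(-c2cccc(O)c2)cc1`: > 26000 nM
Compound 3 `CC(C)N(Cc1cccc(OCCCCCC(=O)O)c1)C(=O)c1ccc(-c2c[nH]c3ccccc23)cc1`: > 26000 nM

Compound 3 has no number and stands only at a limit, (the limit of > 26000 nM in this assay, at which 2 of the 3 values shown sit). Compound 4 `CC(C)N(Cc1cccc(OCCCCCC(=O)O)c1)C(=O)c1ccc(-c2cccc(Cl)c2)cc1` differs from it in one place, with 3-chlorophenyl in place of 1H-indol-3-yl on an aromatic carbon.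

Two measured steps changed this same carbon, a step that the two limits leave unreadable from compound 1 to compound 3 and a step that the two limits leave unreadable from compound 2 to compound 3, and neither has a readable size. The third, a step that the two limits leave unreadable from compound 1 to compound 2, is equally unreadable. Compound 1, with 3-ethoxyphenyl, stands at the limit > 20800 nM. Compound 2, with 3-hydroxyphenyl, stands at the limit > 26000 nM. These compounds give no direction, so no step beyond the usual scatter is expected in this assay, and compound 4 will probably also return only a limit. The expected size is a number no higher from compound 3 to compound 4 (the limit leaves the size open). For compound 4, the estimated value is 26000 nM, with an expected range from 13000 nM to 40000 nM.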

Compound 4, half-maximal effective concentration: > 21900 nM
Compound 4 gave a limit, no number; the forecaster's own chance of this, stated with the estimate: 85%; the middle value is on the limit's open side.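

In this assay compound 4 gives only a limit, like compound 1, compound 2 and compound 3, and none of the steps joining compound 4 to those three can be read. The compounds shown leave open whether the groups on this aromatic carbon differ at all in this assay.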